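A few compounds are considered here, and "the series" means these few. Any claim that something is new, unique, unknown or untested is made for them only; others in the source may bear on it.

Among the compounds with values here, compound 1 `CN1CCN(c2ccc(Nc3ncc4nc(Nc5ccccc5)n([C@H]5CCN(C(=O)OC(C)(C)C)C5)c4n3)cc2)CC1` holds the lower of the two numbers measured so far in a functional assay on HCC827 cells (Homo sapiens) for antiproliferative activity, read by MTT assay, with a stated time of 72 h; a higher number here means a weaker inhibitor, a lower number a stronger inhibitor: compound 1 gives 110 nM, whereas compound 2 `CN1CCN(c2ccc(Nc3ncc4nc(Nc5ccc(F)cc5)n([C@H]5CCN(C(=O)OC(C)(C)C)C5)c4n3)cc2)CC1` gives 580 nM, the difference being a 5.3-fold higher number from compound 1 to compound 2 (0.72 log units; beyond the scatter) after fluoro in place of hydrogen on an aromatic carbon. Compound 3 `CC(=O)N1CC[C@H](n2c(Nc3ccccc3)nc3cnc(Nc4ccc(N5CCN(C)CC5)cc4)nc32)C1` departs from compound 1 at a different place: methyl in place of tert-butoxy on a carbonyl carbon, the carbonyl carbon in question having an amide-type nitrogen in a ring as its other neighbour, so that tert-butoxycarbonyl becomes acetyl. Within the data shown here, the single measured step concerns the aromatic ring and says nothing about this carbonyl substituent, so no measured step bears on the change. Without guidance from the numbers, a step of no more than modest size, or none beyond the scatter, is expected in this assay, in either direction. Compound 3 is therefore estimated at 150 nM, in a range from 50 nM to 500 nM, meaning an expected step of a 1.4-fold higher number from compound 1 to compound 3 (0.13 log units; within the scatter).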

Compound 3, half-maximal inhibitory concentration: 260 nM
Beside the measured number, compound 3's estimate is 1.7-fold (0.24 log units) below it, and the stated range covers the measured number.
By their numbers in this assay, from the lowest: compound 1; then compound 3; then compound 2.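

In this assay, the group on this carbonyl carbon proves to be a position where a change can be read: methyl in place of tert-butoxy, which turns tert-butoxycarbonyl into acetyl, gives a 2.4-fold higher number from compound 1 to compound 3 (0.37 log units; beyond the scatter). The step is modest, so the tert-butoxy group is not required for activity in the nanomolar range here, although its removal does not leave the number unchanged. Nothing available explains why the number moves in this direction.

With only tert-butoxy and methyl shown on this carbonyl carbon, it remains open whether the number follows the count of heavy atoms or depends on the particular group, as ethyl, cyclopropyl or an amine there could show. From the compounds shown here alone, it is also open whether the fluoro step on the aromatic ring would carry over to the acetyl compounds.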